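The source may report more compounds than this note shows. Statements on the series, on what has been measured and on what is new or still open speak of the compounds shown alone.

Three compounds share one core and were tested in a functional assay on cells (Cancer cell lines, Homo sapiens) for cytotoxicity, read by sulforhodamine B assay, with a stated time of 48 h; on this read-out higher numbers stand for weaker inhibition of growth and lower numbers for stronger inhibition of growth. Compound 1 `O=C1N=C(N2N=C(c3ccccc3)CC2c2ccccc2O)S/C1=C1/C(=O)Nc2ccccc21` gives 4770 nM. Compound 2 `O=C1N=C(N2N=C(c3ccccc3)CC2c2ccccc2O)S/C1=C1/C(=O)Nc2ccc(Br)cc21` gives 800 nM, and the step of a 6.0-fold lower number from compound 1 to compound 2 (0.78 log units; beyond the scatter) came from bromo in place of hydrogen on an aromatic carbon. Compound 3 `COc1ccc(C2CC(c3ccccc3)=NN2C2=NC(=O)/C(=C3\C(=O)Nc4ccc(Br)cc43)S2)cc1` gives 480 nM; its number is the lowest of the three, with compound 2 nearest and compound 1 furthest, but the step of a 1.7-fold lower number from compound 2 to compound 3 (0.22 log units; within the scatter) was only 4-methoxyphenyl in place of 2-hydroxyphenyl on a saturated ring carbon and stays within the scatter, so compound 3 cannot be set apart from compound 2.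

Compound 4 `COc1ccc(C2=NN(C3=NC(=O)/C(=C4\C(=O)Nc5ccc(Br)cc54)S3)C(c3ccc(OC)cc3)C2)cc1` carries methoxy in place of hydrogen on an aromatic carbon, on a six-membered aromatic ring of carbon only. Within the data shown here, the only step that bears on it is the one from compound 2 to compound 3, where a change on an aryl ring moved the number within the scatter; the bromo step concerned a different place. The step of a 1.1-fold lower number from compound 3 to compound 4 (0.03 log units; within the scatter) is therefore expected to stay within the scatter, with no clear direction. Compound 4 is expected to give about 450 nM in this assay, between 200 nM and 1000 nM.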

Compound 4, concentration for total growth inhibition: 480 nM
Beside the measured number, compound 4's estimate is 1.1-fold (0.03 log units) below it; the range from low to high includes it.
By their numbers in this assay, from the lowest: compounds 3, 4 and 2 (each within the scatter of the next); then compound 1.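

Among these compounds, the first reading at this place, where compounds 1 to 3 all carry an unsubstituted phenyl, shows that in this assay phenyl to 4-methoxyphenyl gave no change at the digits printed from compound 3 to compound 4 (within the scatter). Methoxy on this aromatic carbon, para to a large group, therefore leaves the number within the scatter, unlike the bromo change at a different place, which gave a 6.0-fold lower number from compound 1 to compound 2 (0.78 log units; beyond the scatter). Nothing in the data offered accounts for this result.

As far as these compounds go, whether an amine, a carboxylic acid or a longer chain in place of the methoxy would also stay within the scatter remains open. Also open, from the compounds shown here alone, is whether phenyl to 4-methoxyphenyl would read the same way on a core without the bromo, such as that of compound 1.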